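Aminomethyl replacing aminocarbamoyl in an adenosine series

A few compounds are considered here, and "the series" means these few. Any claim that something is new, unique, unknown or untested is made for them only; others in the source may bear on it.

Measured compounds:
compound 1, `CNc1nc2c(N)ncnc2n1[C@@H]1O[C@H](CN(C)CCCN)[C@@H](O)[C@H]1O` — 440000 nM
compound 2, `CN(CCC(N)=O)C[C@H]1O[C@@H](n2cnc3c(N)ncnc32)[C@H](O)[C@@H]1O` — 7000 nM
compound 3, `CN(CCC(=O)NN)C[C@H]1O[C@@H](n2cnc3c(N)ncnc32)[C@H](O)[C@@H]1O` — 1500 nM

In an assay on isolated protein for inhibition of S-adenosylmethionine decarboxylase proenzyme (Homo sapiens) (on this read-out lower numbers stand for stronger inhibition and higher numbers for weaker inhibition), compound 3 gives the lowest number of the three; its nearest neighbour is compound 2, and compound 1 lies far off. Among the measured compounds shown here, the single step within the set, a 4.7-fold lower number from compound 2 to compound 3 (0.67 log units; beyond the scatter), shows that the terminal end of the chain carries weight in this assay.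

Compound 4, `CN(CCCN)C[C@H]1O[C@@H](n2cnc3c(N)ncnc32)[C@H](O)[C@@H]1O`, has not been measured. Against compound 3 the change is aminomethyl in place of aminocarbamoyl on a saturated chain carbon, two bonds along the chain from an amine nitrogen. For the measured compounds named here, no measured step covers this change directly: the step from compound 2 to compound 3 alters the amide-type nitrogen only, whereas here the whole aminocarbamoyl group is replaced by aminomethyl. Compound 1 also carries a 3-aminopropyl chain, but it differs from compound 4 in more than one place, so it offers no clean comparison; its number is simply far higher than that of compound 3.

Going by the values given here, because the only neighbouring step, a 4.7-fold lower number from compound 2 to compound 3 (0.67 log units; beyond the scatter), shows the chain end moving the number beyond the scatter, some shift is expected here as well, most likely toward a higher number. Compound 4 is estimated at 3000 nM, within 800 nM to 12000 nM, corresponding to an expected step of a 2.0-fold higher number from compound 3 to compound 4 (0.30 log units; within the scatter).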

Compound 4, half-maximal inhibitory concentration: 500000 nM
Beside the measured number, compound 4's estimate is 170-fold (2.22 log units) below it; measured number above the stated range.
By their numbers in this assay, from the lowest: compound 3; then compound 2; then compounds 1 and 4 (each within the scatter of the next).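

In this assay, aminomethyl in place of aminocarbamoyl on a saturated chain carbon gives a far larger change (a 330-fold higher number from compound 3 to compound 4 (2.52 log units; beyond the scatter)) than the amino-for-hydrogen change on the amide-type nitrogen (a 4.7-fold lower number from compound 2 to compound 3 (0.67 log units; beyond the scatter)), so the chain end carries much more weight than the earlier step suggested. The same replacement starting from carbamoyl also gives a large change (a 71-fold higher number from compound 2 to compound 4 (1.85 log units; beyond the scatter)), which places both amide-type chain ends well apart from the 3-aminopropyl chain in this series. With the 3-aminopropyl chain in place, hydrogen in place of methylamino on an aromatic carbon stays within the scatter (a 1.1-fold higher number from compound 1 to compound 4 (0.06 log units; within the scatter)), so on this chain that aromatic position shows no measurable effect in this assay.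

No measurement accompanying these numbers bears on what lies behind the loss.

Still open, on these data alone, is which part of the amide-type end matters, the carbonyl or the terminal nitrogen; a chain ending in a carboxylic acid or a hydroxyl, or a longer chain ending in an amine, would help separate the two. Also open, as far as these compounds go, is whether methylamino on the aromatic carbon remains as silent when paired with the aminocarbamoyl chain end.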